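A Sulfonamide Swap on the Shared Core

The source may report more compounds than this note shows. Statements on the series, on what has been measured and on what is new or still open speak of the compounds shown alone.

compound 1 `O=C(Nc1nc(-c2ccccc2)cs1)c1ccc([N+](=O)[O-])o1`: 41700 nM
compound 2 `O=C(Nc1nc(-c2cccc(NC(=O)C3CC3)c2)cs1)c1ccc([N+](=O)[O-])o1`: 35700 nM

Among the compounds with values here, in an ADME assay on Vero cells (Chlorocebus sabaeus) for cytotoxicity, read by MTT assay, with a stated time of 72 h (on this read-out lower numbers stand for stronger inhibition and higher numbers for weaker inhibition), compound 1 gives 41700 nM, and compound 2 gives 35700 nM; the single measured step is a 1.2-fold lower number from compound 1 to compound 2 (0.07 log units; within the scatter), so the two compounds sit within the scatter of each other. Compound 3 `CS(=O)(=O)Nc1cccc(-c2csc(NC(=O)c3ccc([N+](=O)[O-])o3)n2)c1` differs from compound 1 by methanesulfonamido in place of hydrogen on an aromatic carbon. The step of a 1.2-fold lower number from compound 1 to compound 2 (0.07 log units; within the scatter) bears on this change, as it also replaces hydrogen on an aromatic carbon of compound 1 and moved the number hardly at all. No step beyond the scatter is therefore expected in this assay. Compound 3 is estimated at 38000 nM (range 18000 nM to 80000 nM), an expected step of a 1.1-fold lower number from compound 1 to compound 3 (0.04 log units; within the scatter).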

Compound 3, half-maximal inhibitory concentration: < 2820 nM
Compound 3 gave a limit, no number (the forecaster's own chance of this, stated with the estimate: 10%); middle value at least 13-fold (1.12 log units) away from the limit.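

Compound 3 gives a limit and not a number: the limit of < 2820 nM in this assay, at which 1 of the 3 values shown sits. In this assay, the aromatic carbon is therefore not a silent place: methanesulfonamido gives an at least 14-fold lower number from compound 1 to compound 3 (1.16 log units; beyond the scatter), and methylsulfonyl in place of cyclopropylcarbonyl on the nitrogen gives an at least 12-fold lower number from compound 2 to compound 3 (1.10 log units; beyond the scatter). Among these compounds, what counts is the group on that nitrogen, since compound 2 stays within the scatter of compound 1 and compound 3 does not.

On these data alone, how far compound 3 lies past its limit remains open, and with it the true size of both steps. Also open, as far as these compounds go, is whether a plain amine or an ethylsulfonyl group at this place would follow compound 2 or compound 3.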